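Swapping 1H-pyrrol-2-yl for acetyl on a carbonyl carbon

A few compounds are considered here, and "the series" means these few. Any claim that something is new, unique, unknown or untested is made for them only; others in the source may bear on it.

- compound 1 `CC(=O)C(=O)NCCCCCCC(=O)Nc1ccccc1` reads > 100000 nM as a limit
- compound 2 `C/C(=N\O)C(=O)NCCCCCCC(=O)Nc1ccccc1` reads > 100000 nM as a limit
- compound 3 `O=C(CCCCCNC(=O)c1ccc[nH]1)Nc1ccccc1` reads > 100000 nM as a limit

All of these readings come from a functional assay on HCT-116 cells (Homo sapiens) for inhibition, read by colorimetric assay, with a stated time of 3 days (a higher number here means a weaker inhibitor, a lower number a stronger inhibitor), and none of them is an actual number. Among the compounds with values here, the whole series so far is summed up by the limit of > 100000 nM in this assay, at which 3 of the 3 values shown sit, and it offers no potency to rank. Compound 3 therefore stands only at > 100000 nM as a limit of the assay.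

The next compound is compound 4 `CC(=O)C(=O)NCCCCCC(=O)Nc1ccccc1` and it differs from compound 3 in one place: acetyl in place of 1H-pyrrol-2-yl on a carbonyl carbon.

Within the data shown here, only one measured step touches a group on such a carbonyl carbon, namely a step that the two limits leave unreadable from compound 1 to compound 2 and it gives no size to carry over. Compound 1 bears the same acetyl on a carbonyl carbon and reads > 100000 nM as a limit, so a further limit is the likely outcome here.

No step beyond the scatter is expected in this assay in either direction, and the estimated change reads a number no higher from compound 3 to compound 4 (the limit leaves the size open) as a rough figure only. For compound 4 the expected value is 100000 nM with an estimated range from 40000 nM to 300000 nM in this test.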

Compound 4, half-maximal inhibitory concentration: > 100000 nM
Compound 4 ended at the assay's limit; the forecaster's own chance of this, stated with the estimate: 85%; the middle value sits exactly at the limit.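

On these data alone, no new step can be read: the comparisons of compound 4 with compound 3 and with compound 1 each set one limit against another, so their sizes stay unknown. The compounds shown leave open how strong any of them actually is in this assay, and whether the swap on the carbonyl carbon changes anything: the limit of > 100000 nM in this assay, at which 4 of the 4 values shown sit.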